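Quaternary ammonium acids and sulfonates against gamma-butyrobetaine dioxygenase

The source may report more compounds than this note shows. Statements on the series, on what has been measured and on what is new or still open speak of the compounds shown alone.

Measured compounds, with their values in an assay for inhibition of gamma-butyrobetaine dioxygenase (Homo sapiens), read by HPLC, with stated times of 15 min and 30 min; a lower number here means a stronger inhibitor, a higher number a weaker inhibitor:
- Compound 1, `C[N+]1(CCCC(=O)O)CCCC1`, gives 490 nM.
- Compound 2, `CC[N+](C)(C)CCCS(=O)(=O)[O-]`, gives 6700 nM.
- Compound 3, `C=CC[N+](C)(C)NCCC(=O)[O-]`, gives 119000 nM.

Compound 3 stands highest of the three numbers in this assay, beyond the scatter from compound 2 and further still from compound 1, so it is the weakest inhibitor of the set as measured. Going by the values given here, no pair among the three differs in a single place, so nothing here ties a single change to a step in the numbers.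

Compound 4, `C=C[N+](C)(C)NCCC(=O)[O-]`, is not yet measured. It differs from compound 3 by vinyl in place of allyl on an amine nitrogen. The change is small in size and leaves the charged nitrogen, the hydrazine-type linkage and the carboxylate chain untouched. Nothing in the measured set speaks to shortening this substituent, so the expectation for the step from compound 3 to compound 4 is a change of a 1.1-fold lower number from compound 3 to compound 4 (0.03 log units; within the scatter), that is, no step beyond the scatter. For compound 4 the estimate in this assay is 110000 nM, with a range from 35000 nM to 350000 nM.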

Compound 4, half-maximal inhibitory concentration: 6800 nM
Estimate against measurement, compound 4: 16-fold (1.21 log units) above, and the stated range ends above it.
By their numbers in this assay, from the lowest: compound 1; then compounds 2 and 4 (each within the scatter of the next); then compound 3.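

In this assay, the substituent on this amine nitrogen proves to be a sensitive point: vinyl in place of allyl gives an 18-fold lower number from compound 3 to compound 4 (1.24 log units; beyond the scatter). Going by these compounds alone, this is the first step tied to a single change, and it is large even though the group goes only from 3 heavy atoms to 2, with the double bond outside aromatic rings kept and the rest of the structure unchanged. No measurement bearing on the origin of this step is available.

Whether the step follows the length of the substituent or the place of its double bond stays open, as the compounds shown include no propyl or propargyl group on this nitrogen. Also open, from the compounds shown here alone, is whether vinyl would bring a similar step on the core of compound 1.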